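Smaller Group on the Carbonyl, Same Cell Assay

The source may report more compounds than this note shows. Statements on the series, on what has been measured and on what is new or still open speak of the compounds shown alone.

Two compounds have been run in an ADME assay on MRC5 cells (Homo sapiens) for inhibition, with a stated time of 72 h (on this read-out lower numbers stand for an effect already at smaller amounts and higher numbers for an effect only at larger amounts of compound), so far. Compound 1 `CO[C@H]1CC[C@H](NC(=O)c2n[nH]cc2NC(=O)c2cc(Cl)cc(Cl)c2)CC1` gives 13000 nM in this assay. Compound 2 `COc1cccc(OC)c1C(=O)Nc1c[nH]nc1C(=O)NCc1ccccn1` is of a different build, and in this assay compound 2 reaches only the limit of > 50000 nM, so no number is known for it. Compound 2 therefore sits at the upper edge of what this assay can report, as the limit of > 50000 nM in this assay, at which 1 of the 2 values shown sits, shows, and stands apart from compound 1 for that reason, though no step between the two is given.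

Compound 3 `COC(=O)c1n[nH]cc1NC(=O)c1c(OC)cccc1OC` has not yet been measured. It keeps the core of compound 2 and differs from it in one place: methoxy in place of ((pyridin-2-yl)methyl)amino on a carbonyl carbon. The change removes a larger group and puts a small one in its place, and the rest of the molecule is kept.

With only a limit for compound 2, the step from compound 2 to compound 3 cannot be read from a measured pair. The expectation is that compound 3 stays near the limit, a step that the limit leaves unreadable from compound 2 to compound 3 of no real size beyond the scatter. Compound 3 is thus estimated at 60000 nM, with a range from 20000 nM to 200000 nM.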

Compound 3, half-maximal effective concentration: > 50000 nM
Compound 3: only a limit was reported; the forecaster's own chance of this, stated with the estimate: 70%; the middle value does not contradict the limit.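

No step from compound 2 to compound 3 can be read, because both compounds reach only a limit and not a number: the limit of > 50000 nM in this assay, at which 2 of the 3 values shown sit.

Still open, on these data alone, is whether methoxy in place of ((pyridin-2-yl)methyl)amino on a carbonyl carbon shifts the result in this assay at all, and if so, how far and in which direction.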